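A second bromo on compound 2

The source may hold more compounds than are shown below. What is called first, only, known or untested is meant among the compounds shown, and "the series" means these compounds.

Values so far in a physicochemical assay for lipophilicity (a lower number here means a more polar compound, a higher number a more lipophilic compound), are these:
- compound 1 `c1ccc(OCCc2nc3ccccc3[nH]2)cc1` reads (3.16)
- compound 2 `Brc1ccccc1OCc1nc2ccccc2[nH]1` reads (3.51)
- compound 3 `Brc1ccc(OCc2nc3ccccc3[nH]2)c(Br)c1` reads (4.52)

Compound 2 (3.51) stands second highest of the three, with compound 1 lower (3.16) and compound 3 higher (4.52). Compound 4 `Brc1cccc(Br)c1OCc1nc2ccccc2[nH]1` is not yet measured. It departs from compound 2 by bromo in place of hydrogen on an aromatic carbon. Among the compounds with values here, one measured step bears on this, a number 1.01 log units higher from compound 2 to compound 3 (beyond the scatter) for the same exchange, though on a different aromatic carbon. Within the data shown here, the data hold no step at the carbon concerned, so somewhat less is allowed for. The expectation in this assay is therefore an upward step, estimated as a number 0.89 log units higher from compound 2 to compound 4 (beyond the scatter) in this reading. The estimated value for compound 4 is 4.4 (expected range 4 to 4.8).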

Compound 4, partition coefficient: 4.42
Beside the measured number, compound 4's estimate is 0.02 log units below it; the measured number falls inside the stated range.
By their numbers in this assay, from the lowest: compound 1; then compound 2; then compounds 4 and 3 (each within the scatter of the next).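

In this assay bromo in place of hydrogen on the carbon ortho to a large group and meta to a bromo group gives a number 0.91 log units higher from compound 2 to compound 4 (beyond the scatter) and so this position also takes the exchange with a rise beyond the scatter. The exchange on a different aromatic carbon gave a number 1.01 log units higher from compound 2 to compound 3 (beyond the scatter) and compound 4 and compound 3 lie within the scatter of each other, so the two positions do not separate here. No evidence at hand accounts for the size of this step. As far as these compounds go, whether a chloro or a methyl group on this carbon would give a step of like size stays open, as does what an amine there would do.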